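Chalcone boronic acid series: pyrrolyl to tolyl ketone

The source may hold more compounds than are shown below. What is called first, only, known or untested is meant among the compounds shown, and "the series" means these compounds.

compound 1 `Cn1cccc1C(=O)/C=C/c1ccc2c(c1)B(O)OC2`: > 100000 nM
compound 2 `CCc1ccc(C(=O)/C=C/c2ccc3c(c2)B(O)OC3)cc1`: 9800 nM
compound 3 `O=C(/C=C/c1ccc2c(c1)B(O)OC2)c1ccc(C(F)(F)F)cc1`: 9200 nM

In a functional assay on MDA-MB-231 cells (Homo sapiens) for cytotoxicity, read by MTT assay, with a stated time of 48 h (on this read-out lower numbers stand for stronger inhibition and higher numbers for weaker inhibition), compound 1 is reported only as a limit, > 100000 nM, so it sits at the limit of > 100000 nM in this assay, at which 1 of the 3 values shown sits, with no number of its own. Compound 2 gives 9800 nM and compound 3 gives 9200 nM; the step of a 1.1-fold lower number from compound 2 to compound 3 (0.03 log units; within the scatter) is the only measured one and concerns a substituent swap on a phenyl ketone. For the measured compounds named here, it does not cover the change to compound 4 `Cc1cccc(C(=O)/C=C/c2ccc3c(c2)B(O)OC3)c1`, namely (3-methylphenyl in place of 1-methyl-1H-pyrrol-2-yl on a carbonyl carbon), for which no measured step exists. Because compound 2 gives 9800 nM and compound 3 gives 9200 nM with aryl ketones closest to the 3-methylphenyl ketone, compound 4 is estimated at 10000 nM, between 3000 nM and 40000 nM. That expectation corresponds to the step of an at least 10-fold lower number from compound 1 to compound 4 (1.00 log units; beyond the scatter).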

Compound 4, half-maximal inhibitory concentration: 4500 nM
For compound 4 the middle estimate is 2.2-fold (0.35 log units) above the measured one; low and high end bracket the measured number.
By their numbers in this assay, from the lowest: compound 4; then compounds 3 and 2 (each within the scatter of the next). At a limit, above all of these: compound 1.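

In this assay, 3-methylphenyl in place of 1-methyl-1H-pyrrol-2-yl on a carbonyl carbon gives an at least 22-fold lower number from compound 1 to compound 4 (1.34 log units; beyond the scatter), so this position responds to a change of ring, whereas the earlier measured swap stayed within the scatter. Compound 1 is a limit and not a number, so the step gives only a minimum size: the limit of > 100000 nM in this assay, at which 1 of the 4 values shown sits.

Open, as far as these compounds go, is whether the shift follows the change of ring or the methyl group, which an unsubstituted phenyl ketone would help separate. Also open, from the compounds shown here alone, is how a phenyl ketone carrying an amine or a carboxylic acid would read.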